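Shortening the saturated chain of compound 2

This account rests on a few compounds, and the source may have more. Where it says the series, first, only, none or still open, it means among the compounds named here.

In an ADME assay on HaCaT cells (Homo sapiens) for cytotoxicity, read by sulforhodamine B assay, with a stated time of 48 h (on this read-out lower numbers stand for higher toxicity in this test and higher numbers for lower toxicity in this test), compound 1 `CCCCCC[C@@H](O)C/C=C\CCCCCCCC(=O)N[C@@H](C)c1ccccc1` gives 9.7 ug/mL and compound 2 `CCCCCCCCCCCCCCCCCC(=O)N1CCOCC1` gives 41.5 ug/mL which is the higher of the two numbers, with a gap beyond the scatter. Compound 3 `CCCCCCCCCCCCCCCC(=O)N1CCOCC1` differs from compound 2 by one change (hydrogen in place of ethyl on a saturated chain carbon, ten or more bonds along the chain from a carbonyl carbon), hydrogen in place of ethyl on a saturated chain carbon, ten or more bonds along the chain from a carbonyl carbon. Among the measured compounds shown here, no measured pair shows this kind of change, so only a small move toward a lower number in this assay is expected, none beyond the scatter. The expected step is small (a 1.2-fold lower number from compound 2 to compound 3 (0.07 log units; within the scatter)). The estimate for compound 3 is 35 ug/mL within a range from 15 ug/mL to 80 ug/mL on this read-out.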

Compound 3, concentration lethal to 50% of the cells: 28.9 ug/mL
For compound 3 the middle estimate is 1.2-fold (0.08 log units) above the measured one; low and high end bracket the measured number.
By their numbers in this assay, from the lowest: compound 1; then compounds 3 and 2 (each within the scatter of the next).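

In this assay, among the compounds shown here, hydrogen in place of ethyl on a saturated chain carbon, ten or more bonds along the chain from a carbonyl carbon, gives a 1.4-fold lower number from compound 2 to compound 3 (0.16 log units; within the scatter) and is the only reading of this change. At this chain position, removing the ethyl therefore gives no change that can be told from the scatter. Still open, going by these compounds, is whether a longer chain, or an amine at the chain end, would move the number beyond the scatter. No measured evidence bears on a cause for this step.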